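The compounds below may be only part of what the source reports. "The series", "measured", "known", "first", "only" and "open" are said of these compounds alone.

Working notes on the series, followed in a functional assay on cells for agonist activity at melatonin receptor type 1A (Homo sapiens), read by GTPgammaS binding, with a stated time of 30 min; a lower number here means a smaller maximal response, a higher number a larger maximal response.

Compound 1 `CC(=O)NCCN(C)c1cccc(OCCCCCCOc2cccc(OC(=O)NC3CCCCC3)c2)c1` and compound 2 `CC(=O)NCCN(C)c1cccc(OCCCCCCOc2cccc(O)c2)c1` share one core; compound 3 `CC(=O)NCCN(C)c1cccc(OCCCCOc2cccc(O)c2)c1` and compound 4 `CC(=O)NCCN(C)c1cccc(OCCCCOc2cccc(OC(=O)NC3CCCCC3)c2)c1` share another. The difference between the two cores is not broken down here.

In this assay compound 1 gives 0.71 and compound 2 gives 0.62; the two values lie within the scatter of each other. The change between them is cyclohexylcarbamoyl in place of hydrogen on an oxygen on an aromatic ring; the step it made is a number 0.090 higher from compound 2 to compound 1 (within the scatter), which is within the scatter, so on this core the cyclohexylcarbamoyl group leaves the maximal response essentially unchanged.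

In this assay compound 3 gives 0.27. This is the lowest of the three measured values, beyond the scatter from compound 2 and from compound 1.

Compound 4 carries the same kind of change on the core of compound 3: cyclohexylcarbamoyl in place of hydrogen on an oxygen on an aromatic ring. The surroundings of the place are the same in both pairs. Within the data shown here, the one measured instance of this change, from compound 2 to compound 1, gave a step of a number 0.090 higher from compound 2 to compound 1 (within the scatter), so compound 4 is expected to move from compound 3 by a step of similar size, a number 0.090 higher from compound 3 to compound 4 (within the scatter). Compound 4 is therefore estimated to give 0.36 in this assay, with the expected range running from 0.2 to 0.55. The range is kept wide because the expectation rests on a single measured step, a number 0.090 higher from compound 2 to compound 1 (within the scatter), observed on a different core. A further point is that compound 3 starts from 0.27, a lower response than compound 2 gave.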

Compound 4, intrinsic activity: the largest response reached, as a fraction of the reference agonist's: 0.07
Estimate against measurement, compound 4: 0.29 above, outside the stated range (below it).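

In this assay, cyclohexylcarbamoyl in place of hydrogen on an oxygen on an aromatic ring does not give the same result on the two cores; on the core of compound 3 the step is a number 0.20 lower from compound 3 to compound 4 (beyond the scatter). Set side by side, the two instances of the change disagree: the same change on two cores in this assay, a number 0.090 higher (within the scatter) from compound 2 to compound 1 and a number 0.20 lower (beyond the scatter) from compound 3 to compound 4, 0.29 apart, beyond the scatter of two such steps. This shows that, within these two pairs, the step measured on the core of compound 2 does not carry over to the core of compound 3, but two instances do not show which feature of the cores sets the outcome, nor how the change would behave on any further core.

As far as these compounds go, it remains open whether a core with a longer chain between the two aromatic rings would follow the pair of compound 2 and compound 1 or the pair of compound 3 and compound 4. From the compounds shown here alone, it also remains open whether a smaller group such as methylcarbamoyl, or an aromatic one such as phenylcarbamoyl, in place of cyclohexylcarbamoyl would show the same split between the two cores.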